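The compounds below may be only part of what the source reports. "The series", "measured", "known", "first", "only" and "open" are said of these compounds alone.

Measured so far:
- compound 1, `CN(C)CCCCCCCCCCOc1ccc2oc(-c3ccccc3)cc(=O)c2c1`: 297 nM
- compound 2, `O=c1cc(-c2ccccc2)oc2ccc(OCCCCCCN3CCCC(O)C3)cc12`: 86 nM

Going by the values given here, in an assay on isolated protein (Cavia porcellus) with Sigma non-opioid intracellular receptor 1 (Homo sapiens) as the target, read by radioligand binding (a lower number here means a stronger inhibitor, a higher number a weaker inhibitor), compound 2 has the lowest number of the two, the only neighbour being compound 1, and the step of a 3.5-fold lower number from compound 1 to compound 2 (0.54 log units; beyond the scatter) lies beyond the scatter. Compound 3, `NCCCCCCOc1ccc2oc(-c3ccccc3)cc(=O)c2c1`, is not yet measured; it carries amino in place of 3-hydroxypiperidin-1-yl on a saturated chain carbon, six bonds along the chain from an oxygen on an aromatic ring. Among the compounds with values here, the one measured step concerns a change at the same place of the chain, but a different exchange, so it bears on this one only loosely. The amine end is where the two measured compounds differ, and that change moved the number. The expected step of a 5.8-fold higher number from compound 2 to compound 3 (0.76 log units; beyond the scatter) points upward. Compound 3 is expected at 500 nM, with a range of 150 nM to 2000 nM.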

Compound 3, half-maximal inhibitory concentration: 2100 nM
The estimate for compound 3 lay 4.2-fold (0.62 log units) below the measured number, and the stated range ends below it.
By their numbers in this assay, from the lowest: compound 2; then compound 1; then compound 3.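

Going by these compounds alone, replacing 3-hydroxypiperidin-1-yl with amino gives a 24-fold higher number from compound 2 to compound 3 (1.39 log units; beyond the scatter) in this assay and is the largest step so far, showing that this chain position can tolerate far less change than the first step suggested. Amino in place of 4-(dimethylamino)butyl moves the same way, with a 7.1-fold higher number from compound 1 to compound 3 (0.85 log units; beyond the scatter) leaving compound 3 the weakest of the three. No evidence is available on what lies behind these steps.

Going by these compounds, it remains open whether the ring or its hydroxyl accounts for the difference from amino. Piperidin-1-yl or dimethylamino at this same place would separate those contributions.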